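The source may hold more compounds than are shown below. What is called first, only, known or untested is meant among the compounds shown, and "the series" means these compounds.

Of the compounds shown here, three built on a shared core have been measured in a functional assay on A549 cells (Homo sapiens) for cytotoxicity, read by MTT assay, with a stated time of 48 h; on this read-out higher numbers stand for weaker inhibition and lower numbers for stronger inhibition. Compound 1 `COc1cc(-c2cc(C(=O)Nc3nc4ccc(F)cc4s3)nc3cc(-c4ccccc4)nn23)cc(OC)c1OC` gives 22400 nM, compound 2 `Cc1cc2nc(NC(=O)c3cc(-c4ccc(F)cc4)n4nc(-c5ccccc5)cc4n3)sc2cc1C` gives 12600 nM, and compound 3 `COc1ccc(-c2cc(C(=O)Nc3nc4cc(C)c(C)cc4s3)nc3cc(-c4ccccc4)nn23)cc1` gives 13200 nM. Compound 3 thus stands second highest of the three numbers, and the numbers of compound 2 and of compound 1 both lie within the scatter of its own. Within the data shown here, the only single-place step measured so far, a 1.0-fold higher number from compound 2 to compound 3 (0.02 log units; within the scatter), changed nothing beyond the scatter.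

Compound 4 `COc1cc(-c2cc(C(=O)Nc3nc4cc(C)c(C)cc4s3)nc3cc(-c4ccccc4)nn23)cc(OC)c1OC` has not yet been measured. It differs from compound 3 in one place: 3,4,5-trimethoxyphenyl in place of 4-methoxyphenyl on an aromatic carbon. Among the measured compounds shown here, no measured step exchanges these two groups directly. For the measured compounds named here, compound 1 carries the same 3,4,5-trimethoxyphenyl group as compound 4, but it also differs from compound 3 elsewhere, so its value and that of compound 3 show only that the two numbers lie within the scatter of each other. On this basis compound 4 is expected to show a step of a 1.2-fold higher number from compound 3 to compound 4 (0.08 log units; within the scatter) that does not reach beyond the scatter. Compound 4 is therefore estimated at 16000 nM, with a range from 6000 nM to 45000 nM.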

Compound 4, half-maximal inhibitory concentration: 2340 nM
Estimate against measurement, compound 4: 6.8-fold (0.83 log units) above; measured number outside the range, below it.
By their numbers in this assay, from the lowest: compound 4; then compounds 2, 3 and 1 (each within the scatter of the next).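

In this assay, 3,4,5-trimethoxyphenyl at this place on the six-membered aromatic ring with 2 nitrogen gives a 5.6-fold lower number from compound 3 to compound 4 (0.75 log units; beyond the scatter) when it replaces 4-methoxyphenyl and a 5.4-fold lower number from compound 2 to compound 4 (0.73 log units; beyond the scatter) when it replaces 4-fluorophenyl, so this position responds to the change even though the earlier exchange of fluoro for methoxy stayed within the scatter. The 3,4,5-trimethoxyphenyl group does not set the number on its own, as 5,6-dimethyl-1,3-benzothiazol-2-yl in place of 6-fluoro-1,3-benzothiazol-2-yl on the amide-type nitrogen gives a 9.6-fold lower number from compound 1 to compound 4 (0.98 log units; beyond the scatter) with that group held constant. Nothing at hand explains either effect.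

From the compounds shown here alone, it remains open whether all three methoxy groups are needed, or whether 3,5-dimethoxyphenyl or 3,4-dimethoxyphenyl would give a similar number. Also open, going by these compounds, is how ethoxy groups, hydroxy groups or an amine on this phenyl ring would read out.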